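Lengthening the Alkyl Chain on a Shared Core

This account rests on a few compounds, and the source may have more. Where it says the series, first, only, none or still open, it means among the compounds named here.

Compound 1 `CCNc1c(N(C)CCCN(C)C)c(=O)c1=O` was tested in an ADME assay on Vero cells (Chlorocebus sabaeus) for cytotoxicity, read by resazurin assay, with a stated time of 72 h (a lower number here means a stronger inhibitor, a higher number a weaker inhibitor), where compound 1 gives 900000 nM. Compound 2 `CCCCNc1c(N(C)CCCN(C)C)c(=O)c1=O` gives 439000 nM, and compound 3 `CCCCCCNc1c(N(C)CCCN(C)C)c(=O)c1=O` gives 900000 nM. Compound 1 thus stands level with compound 3 at the digits shown, the two together the highest of the three numbers. Compound 4 `CCCCCCCCNc1c(N(C)CCCN(C)C)c(=O)c1=O` carries a longer chain, the change being (hexyl in place of hydrogen on a saturated chain carbon, two bonds along the chain from a nitrogen on an aromatic ring). The earlier chain extensions bear on this step: a 2.1-fold lower number from compound 1 to compound 2 (0.31 log units; beyond the scatter), while no change at the digits printed from compound 1 to compound 3 (within the scatter); and a 2.1-fold higher number from compound 2 to compound 3 (0.31 log units; beyond the scatter). Lengthening the chain has therefore moved the number only modestly and in no steady direction, so a step within or near the scatter is expected. Compound 4 is estimated at 750000 nM, with a range from 300000 nM to 1500000 nM. This estimate means a 1.2-fold lower number from compound 1 to compound 4 (0.08 log units; within the scatter) is expected.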

Compound 4, half-maximal inhibitory concentration: 1150000 nM
Estimate against measurement, compound 4: 1.5-fold (0.19 log units) below; the measured number falls inside the stated range.
By their numbers in this assay, from the lowest: compound 2; then compounds 1, 3 and 4 (each within the scatter of the next).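

In this assay, the longest chain here brings a 1.3-fold higher number from compound 1 to compound 4 (0.11 log units; within the scatter) and a 1.3-fold higher number from compound 3 to compound 4 (0.11 log units; within the scatter), so adding hexyl at this place leaves the number essentially unmoved. For the compounds shown here, the one gap beyond the scatter that it opens is a 2.6-fold higher number from compound 2 to compound 4 (0.42 log units; beyond the scatter), which is modest and leaves compound 2 as the only compound set apart. Adding ethyl gives steps on two cores that cannot be told apart: the same change on two cores in this assay, a 2.1-fold lower number (0.31 log units; beyond the scatter) from compound 1 to compound 2 and a 1.3-fold higher number (0.11 log units; within the scatter) from compound 3 to compound 4, 2.6-fold (0.42 log units) apart, within the scatter of two such steps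

On these data alone, whether a still longer chain would move the number remains open. So does the effect of an amine or a carboxylic acid in place of the hexyl.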